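Oxalyl series: ethyl ester to pyrrolidinyl amide

The compounds below may be only part of what the source reports. "The series", "measured", "known", "first", "only" and "open" are said of these compounds alone.

The series shares the core of compound 1 `COc1ccc(/C(=C(/CCN=[N+]=[N-])c2ccccc2)c2ccccc2)cc1`, which ends in an azide and in a functional assay on MCF7 cells (Homo sapiens) for cytotoxicity, read by MTT assay, with a stated time of 72 h (on this read-out lower numbers stand for stronger inhibition and higher numbers for weaker inhibition), is reported as "not active" (no number reported). Compound 2 `CCOC(=O)C(=O)NCC/C(=C(\c1ccccc1)c1ccc(OC)cc1)c1ccccc1` instead continues through an amino group into an oxalyl ethyl ester. In this assay compound 2 gives > 50000 nM, which is a limit of the assay and not a number. Going by the values given here, compound 2 therefore sits at the limit of > 50000 nM in this assay, at which 1 of the 2 values shown sits, and no step between measured compounds is available anywhere. Compound 3 `COc1ccc(/C(=C(/CCNC(=O)C(=O)N2CCCC2)c2ccccc2)c2ccccc2)cc1` keeps the whole of compound 2 apart from one change: pyrrolidin-1-yl in place of ethoxy on a carbonyl carbon. Among the compounds with values here, with no measured step to lean on, and with both known compounds returning no usable number, no movement beyond the usual scatter is expected in either direction in this assay. The step from compound 2 to compound 3 is expected to be a step that the limit leaves unreadable from compound 2 to compound 3. Compound 3 is accordingly estimated at 70000 nM, within a range from 20000 nM to 250000 nM, and the most likely outcome is once more a limit rather than a number.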

Compound 3, half-maximal inhibitory concentration: > 50000 nM
Compound 3: no number, only a limit; the forecaster's own chance of this, stated with the estimate: 75%; the middle value lies beyond the limit too.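

In this assay compound 3 gives > 50000 nM, which is a limit of the assay and not a number. Compound 2 also stands at a limit, so no step can be read between compound 2 and compound 3. The compounds shown leave open how pyrrolidin-1-yl and ethoxy on this carbonyl carbon compare in this assay.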